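Swapping the Aryl Group on a Shared Core

The source may report more compounds than this note shows. Statements on the series, on what has been measured and on what is new or still open speak of the compounds shown alone.

Of the compounds shown here, two have been measured in a functional assay on the whole organism (strain albino) for inhibition, with Rattus norvegicus as the target, read by paw edema, with stated times of 1 h and 3 h, at a dose of 25 mg/kg by the oral route; on this read-out higher numbers stand for more inhibition at the one dose given (going by the name of the read-out) and lower numbers for less inhibition. Compound 1 `COc1ccc(/C=c2/sc3n(c2=O)C(c2ccc([N+](=O)[O-])cc2)C(C(=O)Nc2ccc(F)cc2)=C(C)N=3)cc1` gives 12%. Compound 2 `CC1=C(C(=O)Nc2ccc(F)cc2)C(c2ccc(Cl)cc2)n2c(s/c(=C/c3ccc(Br)cc3)c2=O)=N1` gives 35%, the higher of the two numbers, and its difference from compound 1 lies beyond the scatter. Compound 3 `CC1=C(C(=O)Nc2ccc(F)cc2)C(c2ccc(Cl)cc2)n2c(s/c(=C/c3ccc(Cl)cc3Cl)c2=O)=N1` is not yet measured. It differs from compound 2 by 2,4-dichlorophenyl in place of 4-bromophenyl on a double-bonded chain carbon bound to an aromatic carbon. Among the compounds with values here, no measured pair follows this change, so the expectation rests on compound 2 alone. In this assay compound 3 is expected to stay close to compound 2, with a step of a number 4 percentage points lower from compound 2 to compound 3 (within the scatter) expected to be no larger than the scatter, in either direction. Compound 3 is therefore estimated at 31%, with a range from 16% to 47%.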

Compound 3, a percentage reported as inhibition, in the whole organism at one dose (the size of the read-out at that dose, not a potency): 14%
Beside the measured number, compound 3's estimate is 17 percentage points above it, and the stated range ends above it.
By their numbers in this assay, from the lowest: compounds 1 and 3 (each within the scatter of the next); then compound 2.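

In this assay, within the data shown here, the group on the double-bonded chain carbon bound to an aromatic carbon proves to matter: 2,4-dichlorophenyl in place of 4-bromophenyl gives a number 21 percentage points lower from compound 2 to compound 3 (beyond the scatter), the first one-place step on the shared core. Nothing at hand accounts for this step.

The two compounds change the bromine and the chlorines together, so the step cannot be assigned to either alone. As far as these compounds go, whether 4-chlorophenyl, or a phenyl ring carrying an amine or a carboxylic acid, would hold the number at this place remains open.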